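A few compounds are considered here, and "the series" means these few. Any claim that something is new, unique, unknown or untested is made for them only; others in the source may bear on it.

In a functional assay on PC-3 cells (Homo sapiens) for inhibition, read by colorimetric assay and MTT assay, with a stated time of 72 h (a lower number here means a stronger inhibitor, a higher number a weaker inhibitor), compound 1 (`C=CCCCCOc1ccccc1-c1cnc(OCCC=C)n1C`) gives 19000 nM and sits within the scatter of compound 3 (`C=CCCOc1ncc(-c2ccccc2OC)n1C`), which gives 25000 nM in the same read-out. Compound 2 (`C=CCCCCOc1cc(F)ccc1-c1cnc(OCCC=C)n1C`) gives 64000 nM and stands apart from compound 1. Two measured steps start from compound 1: a 3.4-fold higher number from compound 1 to compound 2 (0.53 log units; beyond the scatter) for fluoro in place of hydrogen on an aromatic carbon, and a 1.3-fold higher number from compound 1 to compound 3 (0.12 log units; within the scatter) for hydrogen in place of pent-4-en-1-yl on a saturated chain carbon bound to an oxygen on an aromatic ring. Compound 4 (`C=CCCCCOc1ccccc1-c1cnc(S(=O)(=O)c2ccccc2)n1C`) brings a different change, phenylsulfonyl in place of (but-3-en-1-yl)oxy on an aromatic carbon with phenylsulfonyl in place of (but-3-en-1-yl)oxy on an aromatic carbon between two ring nitrogen atoms. Neither measured step touches that place, so both serve only as a gauge of size in this assay and give no direction. Going by the values given here, no measured compound carries phenylsulfonyl, and the range stays wide. The estimate for compound 4 is 20000 nM with an expected range from 5000 nM to 70000 nM for now. That estimate means an expected 1.1-fold higher number from compound 1 to compound 4 (0.02 log units; within the scatter) and no firm shift in either direction.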

Compound 4, half-maximal inhibitory concentration: 33000 nM
Beside the measured number, compound 4's estimate is 1.7-fold (0.22 log units) below it, and the stated range covers the measured number.
By their numbers in this assay, from the lowest: compounds 1, 3, 4 and 2 (each within the scatter of the next, the first and the last beyond it).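

In this assay, phenylsulfonyl in place of (but-3-en-1-yl)oxy on the aromatic carbon between two ring nitrogen atoms gives a 1.7-fold higher number from compound 1 to compound 4 (0.24 log units; within the scatter). Going by these compounds alone, none of the earlier compounds varied this place, so this is its first reading: an open chain ending in a double bond and a larger group carrying a six-membered aromatic ring give numbers that cannot be told apart. Nothing available explains this result.

Still open, as far as these compounds go, is whether an amine, a carboxylic acid or a longer chain at this place would move the number beyond the scatter. Also open, from the compounds shown here alone, is whether phenylsulfonyl would read the same on the core of compound 2 or compound 3, which differ from compound 1 elsewhere.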